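This account rests on a few compounds, and the source may have more. Where it says the series, first, only, none or still open, it means among the compounds named here.

Compounds measured so far:
compound 1, `O=C(Nc1ccccc1)c1cccc(/C=C2\CC(=O)N(c3ccccc3)C2=O)c1` — > 100000 nM
compound 2, `Cc1ccc(N2C(=O)C/C(=C\c3cccc(C(=O)Nc4ccc(Cl)cc4)c3)C2=O)cc1` — > 100000 nM
compound 3, `COc1ccc(NC(=O)c2cccc(/C=C3\CC(=O)N(c4ccc(C)cc4)C3=O)c2)cc1` — 93000 nM

The read-out is an ADME assay on SW480 cells (Homo sapiens) for cytotoxicity, read by MTT assay, with a stated time of 72 h; a higher number here means a weaker inhibitor, a lower number a stronger inhibitor. Compound 1 gives no number here; its value of > 100000 nM is a limit of the assay. Compound 2 likewise returns only a limit, > 100000 nM. Compound 3 alone yields a number, 93000 nM. For the measured compounds named here, the one single-point step on record, methoxy in place of chloro on an aromatic carbon, reads an at least 1.0-fold lower number from compound 2 to compound 3 (0.03 log units; that floor lies within the scatter), which lies within the scatter. The series is thus anchored by the limit of > 100000 nM in this assay, at which 2 of the 3 values shown sit, with no change yet resolved beyond it.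

Compound 4 is `O=C(Nc1ccc(F)cc1)c1cccc(/C=C2\CC(=O)N(c3ccccc3)C2=O)c1`. It differs from compound 1 by fluoro in place of hydrogen on an aromatic carbon. Going by the values given here, the only measured step that touches the same region, from compound 2 to compound 3, swapped one group for another on that aromatic carbon without moving the number, so a single fluoro in place of hydrogen gives no grounds for a step in this assay beyond the scatter. The step expected is a number no higher from compound 1 to compound 4 (the limit leaves the size open). Compound 4 is therefore estimated at 100000 nM, with a range from 50000 nM to 200000 nM, and most likely another limit.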

Compound 4, half-maximal inhibitory concentration: > 100000 nM
Compound 4 was reported as a limit (the forecaster's own chance of this, stated with the estimate: 70%); the middle value sits exactly at the limit.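

Compound 1 and compound 4 both return only limits, so no step can be read between them. Whether fluoro in place of hydrogen on this aromatic carbon changes the read-out at all stays open, and the compounds shown give no measured number for either member of this pair, as the series rests on one limit: the limit of > 100000 nM in this assay, at which 3 of the 4 values shown sit.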